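A few compounds are considered here, and "the series" means these few. Any claim that something is new, unique, unknown or untested is made for them only; others in the source may bear on it.

Measured compounds in the series:
- compound 1 `CC(C)(C)Cc1c(-c2cccc(F)c2F)sc(N)c1C(=O)c1ccc(Cl)cc1`, giving 1% in an assay on CHO cells for displacement of a labelled ligand from adenosine receptor A3 (Homo sapiens), read by scintillation counting, tested at 10 uM; on this read-out higher numbers stand for more inhibition at the one concentration tested (going by the name of the read-out) and lower numbers for less inhibition
- compound 2 `Cc1ccccc1-c1sc(N)c(C(=O)c2ccc(Cl)cc2)c1CC(C)(C)C`, giving 1% in this assay

Compound 2 stands level with compound 1 on the numbers shown; the only measured step, no change at the digits printed from compound 1 to compound 2 (within the scatter), lies within the scatter, so swapping one aryl group for another on the aromatic carbon next to the ring sulfur has so far left the read-out where it was. Both measured values sit at the floor of the read-out.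

The next compound is compound 3 `COc1ccc(-c2sc(N)c(C(=O)c3ccc(Cl)cc3)c2CC(C)(C)C)cc1`, which differs from compound 2 as follows: 4-methoxyphenyl in place of 2-methylphenyl on an aromatic carbon. For the measured compounds named here, the one step that bears on this change is the aryl swap from compound 1 to compound 2, and that step was flat. With no evidence of movement from either measured compound, the expected step is a number 2 percentage points higher from compound 2 to compound 3 (within the scatter), none beyond the scatter. Compound 3 is therefore estimated at 3%, with a range from 0% to 15%.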

Compound 3, a percentage reported as inhibition, at one concentration (the size of the read-out at that concentration, not a potency): 2%
Compound 3: the middle estimate sits 1 percentage points above what was measured; the range from low to high includes it.
By their numbers in this assay, from the lowest: compounds 1, 2 and 3 (each within the scatter of the next).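

At the aromatic carbon next to the ring sulfur, 4-methoxyphenyl adds an oxygen and a hydrogen-bond acceptor to the aryl group, yet this assay gives a number 1 percentage points higher from compound 2 to compound 3 (within the scatter) and a number 1 percentage points higher from compound 1 to compound 3 (within the scatter). A third aryl group, now carrying its substituent in a different place and of a different kind, therefore still leaves the read-out at its floor, where these small steps cannot separate the three groups. No measurement offered here accounts for this flat result.

Open, on these data alone, is whether a carboxylic acid or a piperidine in place of the aryl group at this position would lift the read-out off the floor. Also open, as far as these compounds go, is whether a cyclohexyl group in place of the neopentyl group would change the read-out with any of these aryl groups in place.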